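Compound 1 to compound 3: replacing 4-methylphenyl with hydroxy

The compounds below may be only part of what the source reports. "The series", "measured", "known", "first", "only" and "open" are said of these compounds alone.

- compound 1 `Cc1ccc(-c2ncnc3c2ncn3C[C@@H]2C[C@H](CO)c3ccccc32)cc1` gives 1.4 ug/mL in a functional assay on CCRF-CEM cells (Homo sapiens); on this read-out lower numbers stand for stronger inhibition and higher numbers for weaker inhibition
- compound 2 `CCOc1ncnc2c1ncn2C[C@@H]1C[C@H](CO)c2ccccc21` gives 24 ug/mL in this assay

Compound 1 has the lower of the two numbers and is the stronger inhibitor of the pair, as its step to compound 2 lies beyond the scatter. Compound 3 `OC[C@H]1C[C@@H](Cn2cnc3c(O)ncnc32)c2ccccc21` has not yet been measured. It differs from compound 1 by hydroxy in place of 4-methylphenyl on an aromatic carbon in short, hydroxy in place of 4-methylphenyl on an aromatic carbon. Among the measured compounds shown here, one measured step bears on this change, the swap of 4-methylphenyl for ethoxy on an aromatic carbon, which gives a 17-fold higher number from compound 1 to compound 2 (1.23 log units; beyond the scatter) in this assay and is the only guide available. For the measured compounds named here, no hydroxy compound has been measured, so the size of the new step remains uncertain, but a large step in the same direction, toward weaker inhibition, is expected. The expected step is a 21-fold higher number from compound 1 to compound 3 (1.33 log units; beyond the scatter) on this reasoning. For compound 3 the estimated value is 30 ug/mL with an expected range from 8 ug/mL to 100 ug/mL in this assay for now.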

Compound 3, half-maximal inhibitory concentration: 24 ug/mL
The estimate for compound 3 lay 1.3-fold (0.10 log units) above the measured number; measured number inside the range.
By their numbers in this assay, from the lowest: compound 1; then compounds 2 and 3 (each within the scatter of the next).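

In this assay, hydroxy in place of 4-methylphenyl on this aromatic carbon gives a 17-fold higher number from compound 1 to compound 3 (1.23 log units; beyond the scatter) and so provides a second replacement, after ethoxy, that lacks the six-membered aromatic ring of 4-methylphenyl and lies beyond the scatter from compound 1. Loss of the ethyl from the oxygen gives no change at the digits printed from compound 2 to compound 3 (within the scatter) and places this step within the scatter, so the two oxygen-linked groups cannot be told apart on this read-out, and the ethyl shows no measurable contribution at this position. Among these three compounds, only compound 1 stands apart from the others, and no supporting data explain the difference.

Going by these compounds, it remains open whether the lower number of compound 1 depends on the aromatic ring, on the 4-methyl group or on the carbon link to the core, a question that unsubstituted phenyl, a short alkyl chain such as propyl or a saturated ring such as cyclohexyl on the same carbon could help separate. An amine at this position would also show whether the pattern shared by compound 2 and compound 3 extends beyond oxygen-linked groups.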